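The compounds below may be only part of what the source reports. "The series", "measured", "known", "first", "only" and "open" are said of these compounds alone.

Measured compounds:
Compound 1 `C=CCOc1c(Cl)cccc1C(=O)c1cccnc1` — 92000 nM
Compound 2 `O=C(c1cccnc1)c1cccc(Cl)c1O` — 28000 nM
Compound 3 `C=CCOc1ccc(C)cc1C(=O)c1cccnc1` — 72000 nM

These three were tested in a functional assay on Hep cells (Homo sapiens) for cytotoxicity, read by sulforhodamine B assay, with a stated time of 48 h; a higher number here means a weaker inhibitor, a lower number a stronger inhibitor. Compound 1 gives 92000 nM, compound 2 gives 28000 nM, and compound 3 gives 72000 nM. Compound 1 and compound 2 differ in one place only, (hydrogen in place of allyl on an oxygen on an aromatic ring), and that change produced a 3.3-fold lower number from compound 1 to compound 2 (0.52 log units; beyond the scatter). Compound 3 and compound 1 share the same kind of build but differ in their cores; how the two cores differ is not broken down here.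

Compound 4 `Cc1ccc(O)c(C(=O)c2cccnc2)c1` has not yet been tested in this assay. It differs from compound 3 by hydrogen in place of allyl on an oxygen on an aromatic ring, which is the same change already seen from compound 1 to compound 2, made at the same place. If the change behaves the same way on the core of compound 3, the expected step from compound 3 to compound 4 is a 3.3-fold lower number from compound 3 to compound 4 (0.51 log units; beyond the scatter), and this expectation rests on the step of a 3.3-fold lower number from compound 1 to compound 2 (0.52 log units; beyond the scatter). On that basis compound 4 is estimated to give 22000 nM in this assay, most likely between 9000 nM and 55000 nM.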

Compound 4, half-maximal inhibitory concentration: 11000 nM
Compound 4: the middle estimate sits 2.0-fold (0.30 log units) above what was measured, within the range that was stated.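

Replacing the allyl on the oxygen with hydrogen, which turns allyloxy into hydroxy, again lowers the number in this assay, giving a 6.5-fold lower number from compound 3 to compound 4 (0.82 log units; beyond the scatter). The change therefore carries over from the core of compound 1 to the core of compound 3 in the same direction, and the two step sizes cannot be told apart: the same change on two cores in this assay, a 3.3-fold lower number (0.52 log units; beyond the scatter) from compound 1 to compound 2 and a 6.5-fold lower number (0.82 log units; beyond the scatter) from compound 3 to compound 4, 2.0-fold (0.30 log units) apart, within the scatter of two such steps. Among the compounds shown here, with only two pairs, this shows that the step held on these two cores, but it does not show that it would hold on any other core, nor why the hydroxy compounds give the lower numbers.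

The compounds shown leave open whether a different group on that oxygen, such as a methyl or a longer chain, would give a number closer to the allyl compounds or to the hydroxy compounds. Going by these compounds, it also remains open whether the same step would appear on a core carrying an amine or a carboxylic acid.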